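A few compounds are considered here, and "the series" means these few. Any claim that something is new, unique, unknown or untested is made for them only; others in the source may bear on it.

Of the compounds shown here, three have been measured in an ADME assay on a cell-free system (plasma, Homo sapiens) for metabolic stability, read by HPLC; on this read-out higher numbers stand for a longer-lived compound and lower numbers for a shorter-lived compound. Compound 2 `CN(/N=N/c1ccc(Br)cc1)C(=O)CCCCc1ccc(O)cc1` carries a bromo group on one aromatic ring and gives 162 h, the highest of the three numbers. Compound 3 `CN(/N=N/c1ccc(C#N)cc1)C(=O)CCCCc1ccc(O)cc1`, with cyano in place of bromo on that aromatic carbon, gives 11.8 h, and compound 1 `CN(/N=N/c1ccc(C#N)cc1)C(=O)CCc1ccc(O)cc1`, which keeps the cyano group but has a shorter chain to the phenol, gives 5.8 h. Among the measured compounds shown here, the only measured step that changes this position is a 14-fold lower number from compound 2 to compound 3 (1.14 log units; beyond the scatter). Compound 4 `CN(/N=N/c1ccc(C(N)=O)cc1)C(=O)CCCCc1ccc(O)cc1` is the next compound to be measured, and it differs from compound 2 in a single place: carbamoyl in place of bromo on an aromatic carbon. For the measured compounds named here, no compound with a carbamoyl group has yet been measured, so the only guidance is the step from compound 2 to compound 3, where exchanging the bromo group for another small group lowered the half-life sharply. A downward step in this assay is therefore expected, though its size is uncertain. Compound 4 is estimated at 20 h, with a range from 5 h to 80 h, which corresponds to an expected 8.1-fold lower number from compound 2 to compound 4 (0.91 log units; beyond the scatter).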

Compound 4, half-life: 55.4 h
For compound 4 the middle estimate is 2.8-fold (0.44 log units) below the measured one; the range from low to high includes it.
By their numbers in this assay, from the lowest: compound 1; then compound 3; then compound 4; then compound 2.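

In (this assay), exchanging bromo on this aromatic carbon, para to a large group, gives a drop of variable size: carbamoyl brings a 2.9-fold lower number from compound 2 to compound 4 (0.47 log units; beyond the scatter) and so still falls short of the bromo compound, but by less than the earlier step of a 14-fold lower number from compound 2 to compound 3 (1.14 log units; beyond the scatter) did. The two replacements also differ clearly from each other, with carbamoyl in place of cyano giving a 4.7-fold higher number from compound 3 to compound 4 (0.67 log units; beyond the scatter) and showing that the half-life depends on which group enters, not only on the loss of bromo. Nothing available here accounts for these differences.

Going by these compounds, whether a carboxylic acid or an amine on the same carbon would fall nearer to compound 2 or to compound 3 remains open. So does whether carbamoyl would still exceed cyano with the shorter chain of compound 1.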